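Working notes: from 4-nitrobenzyl to 2,6-difluorobenzyl

The source may hold more compounds than are shown below. What is called first, only, known or untested is meant among the compounds shown, and "the series" means these compounds.

Measured compounds in a functional assay on Bel7402/5-FU cells (Homo sapiens) for antiproliferative activity, read by MTT assay, with a stated time of 72 h; a higher number here means a weaker inhibitor, a lower number a stronger inhibitor
- Compound 1 `C=C1C(=O)O[C@H]2[C@H]1CC/C(COC(=O)Cn1cc(F)c(=O)n(Cc3ccccc3)c1=O)=C\CC[C@@]1(C)O[C@@H]21` gives 4270 nM
- Compound 2 `C=C1C(=O)O[C@H]2[C@H]1CC/C(COC(=O)Cn1cc(F)c(=O)n(Cc3ccc(Br)cc3)c1=O)=C\CC[C@@]1(C)O[C@@H]21` gives 3240 nM
- Compound 3 `C=C1C(=O)O[C@H]2[C@H]1CC/C(COC(=O)Cn1cc(F)c(=O)n(Cc3ccc([N+](=O)[O-])cc3)c1=O)=C\CC[C@@]1(C)O[C@@H]21` gives 4340 nM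

Compound 3, at 4340 nM in this assay, holds no separate place in this set, since its values and those of compound 1 and compound 2 lie within the scatter of each other. The next structure is compound 4 `C=C1C(=O)O[C@H]2[C@H]1CC/C(COC(=O)Cn1cc(F)c(=O)n(Cc3c(F)cccc3F)c1=O)=C\CC[C@@]1(C)O[C@@H]21`, which carries 2,6-difluorophenyl in place of 4-nitrophenyl on a saturated chain carbon bound to an aromatic nitrogen. For the measured compounds named here, three measured steps bear on this change. Nitro in place of hydrogen gives a 1.0-fold higher number from compound 1 to compound 3 (0.01 log units; within the scatter) and bromo in place of hydrogen gives a 1.3-fold lower number from compound 1 to compound 2 (0.12 log units; within the scatter), while nitro in place of bromo gives a 1.3-fold higher number from compound 2 to compound 3 (0.13 log units; within the scatter) as the third. All three stay within the scatter. Going by the values given here, no measured compound carries the 2,6-difluorophenyl group, so this evidence is indirect and the range is kept wide. An estimated 1.1-fold lower number from compound 3 to compound 4 (0.05 log units; within the scatter) is expected, which amounts to no step beyond the scatter in either direction. Compound 4 is estimated at 3900 nM (expected range 1800 nM to 8000 nM).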

Compound 4, half-maximal inhibitory concentration: 4980 nM
Compound 4: the middle estimate sits 1.3-fold (0.11 log units) below what was measured; the range from low to high includes it.
By their numbers in this assay, from the lowest: compounds 2, 1, 3 and 4 (each within the scatter of the next).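

In this assay, 2,6-difluorophenyl on a saturated chain carbon bound to an aromatic nitrogen differs from the earlier groups, which were phenyl and two 4-substituted phenyls, yet it gives a 1.1-fold higher number from compound 3 to compound 4 (0.06 log units; within the scatter) and a 1.5-fold higher number from compound 2 to compound 4 (0.19 log units; within the scatter) and a 1.2-fold higher number from compound 1 to compound 4 (0.07 log units; within the scatter), each step within the scatter. The change from 4-nitrobenzyl to 2,6-difluorobenzyl therefore extends the flat reading at this position to a fourth group, and phenyl, 4-bromophenyl, 4-nitrophenyl and 2,6-difluorophenyl cannot be told apart here. No measurement at hand accounts for this flat reading.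

As far as these compounds go, whether a benzyl group bearing an amine or a carboxylic acid, or a longer chain in place of benzyl, would give a step beyond the scatter remains open. From the compounds shown here alone, all four readings come from this assay, so it also remains open whether these groups would stay equally close together in any other cell-based test.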